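Acyl thiosemicarbazide series: swapping the aryl group on compound 1

This account rests on a few compounds, and the source may have more. Where it says the series, first, only, none or still open, it means among the compounds named here.

Within the data shown here, compound 1 (`COc1cc2ncnc(NNC(=S)NC(=O)c3ccc(F)cc3)c2cc1OC`) gives 16100 nM in a functional assay on CNE-2 cells (Homo sapiens) for cytotoxicity, read by MTT assay, with a stated time of 72 h (on this read-out higher numbers stand for weaker inhibition and lower numbers for stronger inhibition), the highest number among the three measured members. Compound 2 (`O=C(NC(=S)NNc1ncnc2ccccc12)c1ccc(F)cc1`) gives 2840 nM, and compound 3 (`O=C(NC(=S)NNc1ncnc2ccccc12)c1ccc(Cl)cc1`) gives 1530 nM; compound 1 stands well above both, with the gap to compound 2 and to compound 3 lying beyond the scatter. Compound 2 and compound 3 lack the two methoxy groups of the shared core of compound 1.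

Compound 4 (`COc1cc2ncnc(NNC(=S)NC(=O)c3ccccc3C)c2cc1OC`) is the not yet measured analogue of compound 1 in which the change is 2-methylphenyl in place of 4-fluorophenyl on a carbonyl carbon. Among the measured compounds shown here, the only measured step that touches the same aryl group is the one from compound 2 to compound 3, with a 1.9-fold lower number from compound 2 to compound 3 (0.27 log units; within the scatter), where chloro replaces fluoro; it stays within the scatter. That step concerns a different substituent on the shared core and a different replacement, so it bears only loosely on the present change. Nothing measured here separates a fluoro from a methyl on that ring. The expectation in this assay is therefore no step beyond the scatter, with a 1.2-fold lower number from compound 1 to compound 4 (0.06 log units; within the scatter) as the estimated shift. Compound 4 is expected to give about 14000 nM, in a range of 5000 nM to 40000 nM.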

Compound 4, half-maximal inhibitory concentration: 10500 nM
Compound 4: middle estimate off by 1.3-fold (0.12 log units), on the high side; the range from low to high includes it.
By their numbers in this assay, from the lowest: compounds 3 and 2 (each within the scatter of the next); then compounds 4 and 1 (each within the scatter of the next).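

In this assay, the core of compound 1 now has a step of its own at the aryl group on the carbonyl carbon, a 1.5-fold lower number from compound 1 to compound 4 (0.19 log units; within the scatter), so 2-methylphenyl in place of 4-fluorophenyl leaves the number within the scatter on the methoxy-bearing core. Among these compounds, the only earlier step at this aryl group, a 1.9-fold lower number from compound 2 to compound 3 (0.27 log units; within the scatter), was read on the core without the two methoxy groups and exchanged one halogen for another, whereas this one replaces the fluoro with a methyl and also differs in where the substituent stands, as the two group names show. Nothing available here explains why the number holds across this change.

Because both features change in one step, the result cannot say whether either alone would leave the number within the scatter, nor whether 2-methylphenyl would read the same on the core without the methoxy groups. Also open, from the compounds shown here alone, is how this position would respond to a more different group, such as an amine or a carboxylic acid on the aryl ring, or a longer alkyl chain in place of that ring.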